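Aryl ring change from compound 3 to compound 4

The source may report more compounds than this note shows. Statements on the series, on what has been measured and on what is new or still open speak of the compounds shown alone.

Measured so far in a functional assay on the whole organism for inhibition, with Mythimna separata as the target, with a stated time of 5 days; on this read-out higher numbers stand for an effect only at larger amounts of compound and lower numbers for an effect already at smaller amounts:
compound 1 `CC(C)(C)n1ncc(OCc2nnc(-c3ccccc3Cl)o2)c(Cl)c1=O` gives 61.2 ug/mL
compound 2 `CCCCn1ncc(OCc2nnc(-c3ccccc3)o2)c(Cl)c1=O` gives a limit, > 300 ug/mL
compound 3 `CC(C)(C)n1ncc(OCc2nnc(-c3cccc(F)c3)o2)c(Cl)c1=O` gives 7.1 ug/mL

Compound 3 stands at the lowest of the two numbers shown, and the nearest measured number is that of compound 1, which lies beyond the scatter. For compound 2 the value is a limit of the assay and not a number (the limit of > 300 ug/mL in this assay, at which 1 of the 3 values shown sits). Compound 4 `CC(C)(C)n1ncc(OCc2nnc(-c3ccc(Cl)cc3)o2)c(Cl)c1=O` differs from compound 3 by 4-chlorophenyl in place of 3-fluorophenyl on an aromatic carbon. For the measured compounds named here, only one measured step bears on the aryl ring, an 8.6-fold lower number from compound 1 to compound 3 (0.94 log units; beyond the scatter), and it exchanged both the halogen and its ring position at once, as the step to compound 4 does again; the 4-chlorophenyl ring itself has not yet been sampled. The direction of that single step therefore cannot simply be carried over, and a step of either sign beyond the scatter remains possible. Compound 4 is estimated at 20 ug/mL (range 5 ug/mL to 80 ug/mL) in this assay, which would mean an expected 2.8-fold higher number from compound 3 to compound 4 (0.45 log units; beyond the scatter).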

Compound 4, half-maximal effective concentration: 1.9 ug/mL
Estimate against measurement, compound 4: 11-fold (1.02 log units) above; the measured number lies below the stated range.
By their numbers in this assay, from the lowest: compound 4; then compound 3; then compound 1. At a limit, above all of these: compound 2.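

In this assay, for the compounds shown here, the 4-chlorophenyl ring gives the lowest number of the series so far, with a 3.7-fold lower number from compound 3 to compound 4 (0.57 log units; beyond the scatter) and, larger still, a 32-fold lower number from compound 1 to compound 4 (1.51 log units; beyond the scatter) as its two steps. Going by these compounds alone, the second of these is the first step in which the halogen stays chlorine and only its ring position differs, so position alone is seen to matter on this aryl ring, whereas the earlier step changed halogen and position together, as the step from the 3-fluorophenyl ring does again. No measured property of these compounds accounts for either step.

The shares of halogen and of position within the step between the 3-fluorophenyl and 4-chlorophenyl rings stay unseparated. Also open, as far as these compounds go, is whether fluorine, a methoxy group or a trifluoromethyl group in place of the chlorine of the 4-chlorophenyl ring would hold this low number.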